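A few compounds are considered here, and "the series" means these few. Any claim that something is new, unique, unknown or untested is made for them only; others in the source may bear on it.

Series values in a functional assay on HT-1080 cells (Homo sapiens) for antiproliferative activity, read by sulforhodamine B assay, with a stated time of 48 h; on this read-out higher numbers stand for weaker inhibition and lower numbers for stronger inhibition:
- compound 1 `Cc1cccc(NS(=O)(=O)c2ccc(N3CCNC3=O)cc2)c1` gives 210 nM
- compound 2 `O=C1NCCN1c1ccc(S(=O)(=O)Nc2cccc(Br)c2)cc1` gives 170 nM
- compound 3 `O=C1NCCN1c1ccc(S(=O)(=O)Nc2cccc(Cl)c2)cc1` gives 68 nM

Compound 3 has the lowest number of the three, and both others lie beyond the scatter from it. Compound 4 `COc1cccc(NS(=O)(=O)c2ccc(N3CCNC3=O)cc2)c1` has methoxy in place of chloro on an aromatic carbon, meta to a large group: methoxy in place of chloro on an aromatic carbon. Within the data shown here, no methoxy compound has been measured yet. The closest evidence is a 3.1-fold lower number from compound 1 to compound 3 (0.49 log units; beyond the scatter) and a 2.5-fold lower number from compound 2 to compound 3 (0.40 log units; beyond the scatter), both modest, while a 1.2-fold lower number from compound 1 to compound 2 (0.09 log units; within the scatter) stays within the scatter. If methoxy tracks methyl and bromo, a modest rise in the number is expected in this assay. The expected step is a 2.6-fold higher number from compound 3 to compound 4 (0.42 log units; beyond the scatter). For compound 4 the estimated value is 180 nM, with an expected range of 60 nM to 500 nM.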

Compound 4, half-maximal inhibitory concentration: 200 nM
Beside the measured number, compound 4's estimate is 1.1-fold (0.05 log units) below it; the measured number falls inside the stated range.
By their numbers in this assay, from the lowest: compound 3; then compounds 2, 4 and 1 (each within the scatter of the next).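

In this assay methoxy on this aromatic carbon, meta to a large group, does not carry the chloro result (a 2.9-fold higher number from compound 3 to compound 4 (0.47 log units; beyond the scatter)). Methoxy reads level with bromo (a 1.2-fold higher number from compound 2 to compound 4 (0.07 log units; within the scatter)) and with methyl (a 1.1-fold lower number from compound 1 to compound 4 (0.02 log units; within the scatter)), which leaves chloro as the only one of the four groups set apart from the rest. Nothing measured here accounts for that separation.

Open, going by these compounds, is how an amine or a carboxylic acid on this carbon would read. Also open, on these data alone, is whether fluoro would follow chloro or fall with the other three groups.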